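Trimming the amide chain: what to expect for compound 4

The compounds below may be only part of what the source reports. "The series", "measured", "known", "first", "only" and "open" are said of these compounds alone.

Compound 1, `COCCOC(=O)c1cc(N)c(Nc2ccc(C#N)cc2)cc1Oc1c(C)cc(/C=C/C#N)cc1C`, in a physicochemical assay for lipophilicity, read by HPLC, measured as octanol-water partition, with a stated time of 24 h, at pH 7.4 (on this read-out higher numbers stand for higher lipophilicity and lower numbers for lower lipophilicity), gives > 5; this is a limit of the assay, not a number.
Compound 2, `CCNC(=O)c1cc(N)c(Nc2ccc(C#N)cc2)cc1Oc1c(C)cc(/C=C/C#N)cc1C`, gives 3.63.
Compound 3, `Cc1cc(/C=C/C#N)cc(C)c1Oc1cc(Nc2ccc(C#N)cc2)c(N)cc1C(=O)NCCC(F)F`, gives 3.58.

Three compounds share one core and differ only in the group on the carbonyl carbon of the amide. Compound 1 sits at the limit of > 5 in this assay, at which 1 of the 3 values shown sits. Among the measured compounds shown here, compound 2 and compound 3 have the only two plain numbers, and they lie within the scatter of each other, as the step of a number 0.05 log units lower from compound 2 to compound 3 (within the scatter) shows. Both steps from compound 1 were large: a number at least 1.37 log units lower from compound 1 to compound 2 (beyond the scatter) and a number at least 1.42 log units lower from compound 1 to compound 3 (beyond the scatter).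

Compound 4, `CNC(=O)c1cc(N)c(Nc2ccc(C#N)cc2)cc1Oc1c(C)cc(/C=C/C#N)cc1C`, has not yet been measured. Its change from compound 3 is hydrogen in place of 2,2-difluoroethyl on a saturated chain carbon bound to an amide-type nitrogen. For the measured compounds named here, no measured step removes carbon and fluorine together in this way. The step of a number 0.05 log units lower from compound 2 to compound 3 (within the scatter) shows that adding difluoromethyl changed little, so most of the difference here lies in the shorter chain. The expected outcome is a modest move downward, a number 0.38 log units lower from compound 3 to compound 4 (beyond the scatter). Compound 4 is therefore expected to give about 3.2, with a likely range from 2.7 to 3.7.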

Compound 4, partition coefficient: 2.65
The estimate for compound 4 lay 0.55 log units above the measured number; measured number outside the range, below it.
By their numbers in this assay, from the lowest: compound 4; then compounds 3 and 2 (each within the scatter of the next). At a limit, above all of these: compound 1.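

In this assay, the amide chain turns out not to be a place where changes pass unnoticed, as the earlier pair of compound 2 and compound 3 might have suggested. Cutting the ethylamino chain down to methylamino, with hydrogen in place of methyl, gives a number 0.98 log units lower from compound 2 to compound 4 (beyond the scatter), and removing 2,2-difluoroethyl gives a number 0.93 log units lower from compound 3 to compound 4 (beyond the scatter), so these are the first steps among the three amides to go beyond the scatter, while adding difluoromethyl gave only a number 0.05 log units lower from compound 2 to compound 3 (within the scatter). The step of a number at least 2.35 log units lower from compound 1 to compound 4 (beyond the scatter) starts from a limit of the assay and not from a number: the limit of > 5 in this assay, at which 1 of the 4 values shown sits.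

The compounds shown leave open whether the number keeps moving along the same line at the ends of this series, for example with a plain amide carrying no chain on its nitrogen, or with a longer unfluorinated chain such as propyl or butyl. They also give no sign of how this read-out would respond to an amine or a carboxylic acid at the end of the amide chain, or to a small ring such as cyclopropyl on the amide nitrogen.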